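A few compounds are considered here, and "the series" means these few. Any claim that something is new, unique, unknown or untested is made for them only; others in the source may bear on it.

Compound 1 `N#CCC(=O)N/N=C(/CBr)c1ccc(Br)cc1` and compound 2 `N#CCC(=O)N/N=C(/CBr)c1ccc([N+](=O)[O-])cc1` share a core that carries a substituted phenyl ring, and compound 3 `N#CCC1=NN=C(c2ccc([N+](=O)[O-])cc2)C(CC(=O)c2ccc([N+](=O)[O-])cc2)O1` is built on a different core; the difference between the two cores is not broken down here. In a functional assay on NCI-H460 cells (Homo sapiens) for inhibition, read by sulforhodamine B assay, with a stated time of 48 h (on this read-out higher numbers stand for weaker inhibition of growth and lower numbers for stronger inhibition of growth), compound 2 gives 10300 nM, and compound 1 gives 10000 nM, so the change bromo in place of nitro on an aromatic carbon made a 1.0-fold lower number from compound 2 to compound 1 (0.01 log units; within the scatter). Compound 3 gives 2600 nM in this assay. Compound 4 `N#CCC1=NN=C(c2ccc([N+](=O)[O-])cc2)C(CC(=O)c2ccc(Br)cc2)O1` differs from compound 3 by bromo in place of nitro on an aromatic carbon, the same change as from compound 2 to compound 1. Because the step of a 1.0-fold lower number from compound 2 to compound 1 (0.01 log units; within the scatter) stayed inside the scatter, compound 4 is expected to make a similarly small step a 1.1-fold higher number from compound 3 to compound 4 (0.03 log units; within the scatter) in this assay. The estimate for compound 4 is therefore 2800 nM, between 1200 nM and 6500 nM.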

Compound 4, concentration for 50% growth inhibition: 40000 nM
Compound 4: the middle estimate sits 14-fold (1.15 log units) below what was measured; the whole stated range lies below it.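

In this assay, the change from 4-nitrophenyl to 4-bromophenyl on the core of compound 3 gave a 15-fold higher number from compound 3 to compound 4 (1.19 log units; beyond the scatter), so growth inhibition was weaker with bromo on this core. The same change did not carry over in size from one core to the other: the same change on two cores in this assay, a 1.0-fold lower number (0.01 log units; within the scatter) from compound 2 to compound 1 and a 15-fold higher number (1.19 log units; beyond the scatter) from compound 3 to compound 4, 16-fold (1.20 log units) apart, beyond the scatter of two such steps This shows that a step lying within the scatter on one core did not predict the step on the other, but it rests on a single pair per core and does not show why the two differ.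

The compounds shown leave open whether the 4-nitrophenyl group retained in compound 4 would respond to bromo in the same way. They also leave open how chloro, an amine or a carboxylic acid in place of nitro would behave on either core.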